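Expected tolerance of a butylsulfanyl analogue on fibroblasts

The compounds below may be only part of what the source reports. "The series", "measured", "known", "first", "only" and "open" are said of these compounds alone.

The three measured compounds share one core and differ only in the group on an aromatic carbon. Compound 1 `Nc1nc(OCc2ccccc2)c2ncn(/C=C3/CC3(CO)CO)c2n1` carries a benzyloxy group there, compound 2 `CCCSc1nc(N)nc2c1ncn2/C=C1/CC1(CO)CO` a propylsulfanyl group, and compound 3 `Nc1nc(NC2CCCC2)c2ncn(/C=C3/CC3(CO)CO)c2n1` a cyclopentylamino group. In an ADME assay on HFF cells (Homo sapiens) for cytotoxicity, with a stated time of 8 days (a higher number here means that more compound is tolerated, a lower number that less compound is tolerated), compound 1 returns only a limit of the assay, > 300000 nM, not a number. In this assay compound 2 likewise returns only a limit, > 300000 nM. In this assay compound 3 also returns only a limit, > 300000 nM. Compound 3 therefore stands at the limit at which all three measured values sit (the limit of > 300000 nM in this assay, at which 3 of the 3 values shown sit), with no number of its own.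

Compound 4 `CCCCSc1nc(N)nc2c1ncn2/C=C1/CC1(CO)CO` has not yet been measured. It differs from compound 3 in one place: butylsulfanyl in place of cyclopentylamino on an aromatic carbon. The measured steps that bear on this change are those involving the cyclopentylamino group, a step that the two limits leave unreadable from compound 1 to compound 3 and a step that the two limits leave unreadable from compound 2 to compound 3, and the one in which the related propylsulfanyl group enters, a step that the two limits leave unreadable from compound 1 to compound 2; none of them can be read, so no size or direction follows from them. Because every measured value sits at the limit (the limit of > 300000 nM in this assay, at which 3 of the 3 values shown sit), compound 4 is expected to sit there too, and the step that the limit leaves unreadable from compound 3 to compound 4 is expected to stay within the scatter. The estimate for compound 4 in this assay is 400000 nM, with a range from 150000 nM to 1000000 nM.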

Compound 4, half-maximal cytotoxic concentration: > 300000 nM
Compound 4 ended at the assay's limit (the forecaster's own chance of this, stated with the estimate: 85%); the middle value is on the limit's open side.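

In this assay, among these compounds, compound 4 also returns only a limit, so no step between compound 4 and compound 1, compound 2 or compound 3 can be read: the limit of > 300000 nM in this assay, at which 4 of the 4 values shown sit. The compounds shown leave open at what concentration any of them harms the cells, and whether the group on the aromatic carbon matters for tolerance at all.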